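Working notes: oxy to amino swap on the side chain

The source may hold more compounds than are shown below. What is called first, only, known or untested is meant among the compounds shown, and "the series" means these compounds.

Values in a functional assay on SK-MEL-5 cells (Homo sapiens) for antiproliferative activity, read by sulforhodamine B assay, with a stated time of 48 h (a higher number here means a weaker inhibitor, a lower number a stronger inhibitor), are as follows
compound 1 `C/C=C(\C)C(=O)O[C@H]1C=CC(=O)O[C@H]1CCC(=O)[C@H](C)O` gives 24000 nM
compound 2 `C/C=C(\C)C(=O)O[C@H]1C=CC(=O)O[C@H]1COC(=O)[C@H](C)O` gives 13000 nM
compound 3 `C/C=C(\C)C(=O)O[C@H]1C=CC(=O)O[C@H]1CNC(=O)[C@H](C)O` is not yet measured

Compound 2 at 13000 nM lies within the scatter of compound 1, so these two numbers set no order. The change leading to compound 3 is ((1-hydroxyethyl)carbonyl)amino in place of ((1-hydroxyethyl)carbonyl)oxy on a saturated chain carbon bound to a saturated ring carbon and it falls on a saturated chain carbon bound to a saturated ring carbon. For the measured compounds named here, one measured step bears on it, a 1.8-fold lower number from compound 1 to compound 2 (0.27 log units; within the scatter) at the same place, and that step stays within the scatter. A single step is thin evidence, but no shift beyond the scatter is expected in this assay in either direction. The expected step is a 1.2-fold higher number from compound 2 to compound 3 (0.06 log units; within the scatter) on this one comparison. For compound 3 the estimated value is 15000 nM with an expected range from 6000 nM to 40000 nM as a working figure.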

Compound 3, half-maximal inhibitory concentration: 28000 nM
The estimate for compound 3 lay 1.9-fold (0.27 log units) below the measured number; the range from low to high includes it.
By their numbers in this assay, from the lowest: compounds 2, 1 and 3 (each within the scatter of the next, the first and the last beyond it).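

Working through this assay at the position on a saturated chain carbon bound to a saturated ring carbon, ((1-hydroxyethyl)carbonyl)amino in place of ((1-hydroxyethyl)carbonyl)oxy gives a 2.2-fold higher number from compound 2 to compound 3 (0.33 log units; beyond the scatter) and is the only step so far to pass the scatter, if only modestly. By contrast, ((1-hydroxyethyl)carbonyl)amino in place of ((1-hydroxyethyl)carbonyl)methyl gives a 1.2-fold higher number from compound 1 to compound 3 (0.07 log units; within the scatter) and sets no order between those two compounds, so the atom linking the side chain matters measurably only in the comparison of the oxy and amino forms. Nothing available accounts for this separation.

Whether the modest step marks a real trend in the linking atom remains unresolved on this single comparison. Also open is how a carboxylic acid, a free amine or a longer chain at this position would read in this assay relative to the three side chains shown.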